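A few compounds are considered here, and "the series" means these few. Any claim that something is new, unique, unknown or untested is made for them only; others in the source may bear on it.

Measured so far:

- compound 1, `COc1cc(Nc2nc3ccccc3nc2S(=O)(=O)c2ccccc2)cc(OC)c1OC`: 9660 nM
- compound 2, `Nc1cccc(Nc2nc3ccccc3nc2S(=O)(=O)c2ccccc2)c1`: 1590 nM
- compound 3, `Cc1ccc(S(=O)(=O)c2nc3ccccc3nc2Nc2cccc(N)c2)cc1`: 1950 nM

In a functional assay on A549 cells (Homo sapiens) for cytotoxicity, read by MTT assay, with a stated time of 72 h (a lower number here means a stronger inhibitor, a higher number a weaker inhibitor), compound 3 stands second highest of the three numbers. Its nearest neighbour is compound 2, and the single-point step a 1.2-fold higher number from compound 2 to compound 3 (0.09 log units; within the scatter) is within the scatter, so the two cannot be ordered. Within the data shown here, compound 1 is the furthest from it; compound 1 differs from compound 3 in more than one place, so no single step links them, and the two values simply show compound 1 sitting well above compound 3.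

Compound 4, `Cc1ccc(S(=O)(=O)c2nc3ccccc3nc2Nc2ccc(C(F)(F)F)cc2)cc1`, is reached from compound 3 by 4-(trifluoromethyl)phenyl in place of 3-aminophenyl on a nitrogen on an aromatic ring. Among the measured compounds shown here, no measured step bears directly on this change: the one step in hand, a 1.2-fold higher number from compound 2 to compound 3 (0.09 log units; within the scatter), concerns a methyl in place of hydrogen on an aromatic carbon and is within the scatter. For the measured compounds named here, the only guide is that the one measured compound carrying substituents other than an amino group on this ring, compound 1, gives the highest number. On that slender basis a moderate rise in this assay is expected for compound 4, with wide uncertainty; the expected step is a 2.3-fold higher number from compound 3 to compound 4 (0.36 log units; beyond the scatter). Compound 4 is estimated at 4500 nM, in the range 1500 nM to 14000 nM.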

Compound 4, half-maximal inhibitory concentration: 13500 nM
For compound 4 the middle estimate is 3.0-fold (0.48 log units) below the measured one; the range from low to high includes it.
By their numbers in this assay, from the lowest: compounds 2 and 3 (each within the scatter of the next); then compounds 1 and 4 (each within the scatter of the next).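

In this assay, the swap on this nitrogen gives a 6.9-fold higher number from compound 3 to compound 4 (0.84 log units; beyond the scatter), so this position responds to the group it carries, whereas the methyl in place of hydrogen on an aromatic carbon gave only a 1.2-fold higher number from compound 2 to compound 3 (0.09 log units; within the scatter). The change is a whole-group exchange: the ring stays a six-membered aromatic ring of carbon only, while the amino group is lost and a trifluoromethyl group enters, so the step cannot be divided between the loss of one and the gain of the other, or between their different places on the ring. No measured data on this series account for the higher number.

Open, on these data alone, is how a plain phenyl group on the same nitrogen would read in this assay, since that one compound would show how much of the step belongs to each side of the exchange. Also open, as far as these compounds go, is whether a hydroxyl group or a carboxylic acid in place of the amino group would keep the number close to that of compound 3, or whether the amino group itself is what matters here.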